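Carboxy to Carboxymethyl on a Sphingosine Receptor Agonist Core

The compounds below may be only part of what the source reports. "The series", "measured", "known", "first", "only" and "open" are said of these compounds alone.

Measured so far:
compound 1, `Cc1ccccc1-c1noc(-c2ccc(C3CCCCC3)cc2)n1`, 266 nM in a functional assay on CHO cells for agonist activity at sphingosine 1-phosphate receptor 5 (Homo sapiens), read by GTPgammaS binding; a lower number here means that less compound is needed, a higher number that more compound is needed for the effect
compound 2, `Cc1cc(C(=O)O)ccc1-c1noc(-c2ccc(C3CCCCC3)cc2)n1`, > 10000 nM

In this assay compound 1 gives 266 nM. For compound 2 the reported figure of > 10000 nM is only a limit of the assay, not a measured number (the limit of > 10000 nM in this assay, at which 1 of the 2 values shown sits). Among the compounds with values here, the only measured step, an at least 37-fold higher number from compound 1 to compound 2 (1.57 log units; beyond the scatter), is carboxy in place of hydrogen on an aromatic carbon, and it cost the activity.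

Compound 3, `Cc1cc(CC(=O)O)ccc1-c1noc(-c2ccc(C3CCCCC3)cc2)n1`, differs from compound 2 by carboxymethyl in place of carboxy on an aromatic carbon. Within the data shown here, both compound 2 and compound 3 carry an acid on the same ring, so the step that bears on this change is the loss seen from compound 1 to compound 2, which suggests that an acid here is poorly tolerated; no measured step shows what lengthening the acid by one carbon does. The step of an at least 1.2-fold lower number from compound 2 to compound 3 (0.09 log units; that floor lies within the scatter) is therefore expected to be small, within the scatter, and compound 3 is estimated at 8000 nM, within 1500 nM to 40000 nM, with a real chance that only a limit is reported again.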

Compound 3, half-maximal effective concentration: 4000 nM
For compound 3 the middle estimate is 2.0-fold (0.30 log units) above the measured one; measured number inside the range.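

In this assay, carboxymethyl in place of carboxy on the aromatic carbon meta to a methyl group gives an at least 2.5-fold lower number from compound 2 to compound 3 (0.39 log units; beyond the scatter), so at this position the result depends on more than the presence of an acid: one extra carbon between ring and acid makes a measurable difference. The figure for compound 2 is a limit of the assay, not a measured number, so this step shows only the smallest possible change: the limit of > 10000 nM in this assay, at which 1 of the 3 values shown sits. Carboxymethyl still recovers only part of the loss, with a 15-fold higher number from compound 1 to compound 3 (1.18 log units; beyond the scatter).

As far as these compounds go, whether a longer chain ending in a carboxylic acid would lower the number further remains open. So does whether hydroxymethyl or a primary amide, which carry no acid, would be better tolerated at this position than carboxymethyl.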